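A few compounds are considered here, and "the series" means these few. Any claim that something is new, unique, unknown or untested is made for them only; others in the source may bear on it.

Working notes on the shared core, read in an assay on isolated protein for inhibition of Indoleamine 2,3-dioxygenase 1 (Homo sapiens), read by spectrophotometry; on this read-out lower numbers stand for stronger inhibition and higher numbers for weaker inhibition. Compound 1 `O/N=C(/Nc1ccccc1)c1ccc2occc2c1` returns only a limit, > 30000 nM, not a number. Two of the three values sit at the limit of > 30000 nM in this assay, at which 2 of the 3 values shown sit. Compound 2 `O/N=C(/Nc1cccc(Cl)c1)c1ccc2occc2c1` gives 690 nM. Compound 3 `O/N=C(/Nc1cccc(Cc2ccccc2)c1)c1ccc2occc2c1` likewise returns a limit, > 30000 nM. The step of an at least 43-fold lower number from compound 1 to compound 2 (1.63 log units; beyond the scatter) is large; the step of an at least 43-fold higher number from compound 2 to compound 3 (1.63 log units; beyond the scatter) is large in the other direction; the step that the two limits leave unreadable from compound 1 to compound 3 cannot be read. Compound 4 `O/N=C(/NCC1CC1)c1ccc2occc2c1` differs from compound 1 by cyclopropylmethyl in place of phenyl on an amine nitrogen. Among the compounds with values here, none of the measured steps alters the group on the amine nitrogen; all three vary a substituent on the phenyl that is now removed, so none bears directly on this change. The step from compound 1 is expected to be a step that the limit leaves unreadable from compound 1 to compound 4. Compound 4 is estimated at 40000 nM, range 8000 nM to 150000 nM, most likely another limit.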

Compound 4, half-maximal inhibitory concentration: > 30000 nM
Compound 4: only a limit was reported; the forecaster's own chance of this, stated with the estimate: 70%; the middle value lies beyond the limit too.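

Compound 4 returns only a limit, > 30000 nM, and compound 1 also stands at a limit; the step between them cannot be read. As far as these compounds go, whether cyclopropylmethyl in place of phenyl on an amine nitrogen changes inhibition stays open.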